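The source may report more compounds than this note shows. Statements on the series, on what has been measured and on what is new or still open speak of the compounds shown alone.

Measured so far:
compound 1, `CC1=NN(C(=O)c2cc3ccccc3oc2=O)C(=O)C1CNc1ccc(C(=O)O)cc1`: 72.6%
compound 2, `CC1=NN(C(=O)c2cc3ccccc3oc2=O)C(=O)C1CNc1ccc([N+](=O)[O-])cc1`: 72%

In a functional assay on the whole organism for inhibition, with Rattus norvegicus as the target, read by paw edema, with stated times of 1 h and 6 h, at a dose of 0.03 mg/kg by the oral route (on this read-out higher numbers stand for more inhibition at the one dose given (going by the name of the read-out) and lower numbers for less inhibition), compound 1 gives 72.6% and compound 2 gives 72%. The number for compound 2 is the lower of the two, but the step of a number 0.6 percentage points lower from compound 1 to compound 2 (within the scatter) lies within the scatter, so the two compounds cannot be told apart on this read-out. Compound 3, `CC1=NN(C(=O)c2cc3ccccc3oc2=O)C(=O)C1CNc1ccc(O)cc1`, has not yet been measured. Its change from compound 2 is hydroxy in place of nitro on an aromatic carbon. Among the compounds with values here, the only measured step that bears on this is the one that likewise swaps the group on that aromatic carbon, a number 0.6 percentage points lower from compound 1 to compound 2 (within the scatter), and it was too small to count; no measured step covers hydroxy itself. No step beyond the scatter is therefore expected in this assay in either direction, and the expected step is a number 2 percentage points lower from compound 2 to compound 3 (within the scatter). Compound 3 is estimated at 70%, with a range from 55% to 85%.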

Compound 3, a percentage reported as inhibition, in the whole organism at one dose (the size of the read-out at that dose, not a potency): 50.7%
Compound 3: middle estimate off by 19.3 percentage points, on the high side; measured number below the stated range.
By their numbers in this assay, from the lowest: compound 3; then compounds 2 and 1 (each within the scatter of the next).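

The ring position para to a large group is not indifferent to what sits on it in this assay: hydroxy in place of nitro gives a number 21.3 percentage points lower from compound 2 to compound 3 (beyond the scatter), and hydroxy in place of carboxy gives a number 21.9 percentage points lower from compound 1 to compound 3 (beyond the scatter). The earlier pair could not be told apart, which could have suggested that the group here hardly matters, but hydroxy shows that this holds at most for nitro and carboxy, and that the read-out can respond to a change at this place. The data on hand offer no explanation for the lower number with hydroxy.

From the compounds shown here alone, it remains open whether the lower number is peculiar to hydroxy or would also come with a methoxy group or an amine at this place. A single dose also leaves open whether the gap between these compounds would persist at other doses.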